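Carbonyl substituent exchange from compound 3 to compound 4

The source may report more compounds than this note shows. Statements on the series, on what has been measured and on what is new or still open speak of the compounds shown alone.

In a physicochemical assay for solubility, read by LC-MS, in phosphate buffer, with a stated time of 24 h, at pH 6.8 (a lower number here means a less soluble compound, a higher number a more soluble compound), compound 1 (`C[C@H](NC(=O)c1cccc(F)c1)c1ccc(NC(=O)N2CC(c3cccnc3)C2)cc1`) gives 11000 nM, compound 2 (`C[C@H](NC(=O)C1CCOCC1)c1ccc(NC(=O)N2CC(c3cccnc3)C2)cc1`) gives 380000 nM and compound 3 (`C[C@H](NC(=O)c1cccc(F)c1)c1ccc(NC(=O)N2CC(c3ccc(N)nc3)C2)cc1`) gives 32000 nM. Compound 3 is thus second highest of the three, above compound 1 and below compound 2.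

Compound 4 (`C[C@H](NC(=O)[C@@H]1CCCN1C)c1ccc(NC(=O)N2CC(c3ccc(N)nc3)C2)cc1`) keeps the amino group of compound 3 but carries 1-methylpyrrolidin-2-yl in place of 3-fluorophenyl on a carbonyl carbon.

The nearest measured precedent is a 35-fold higher number from compound 1 to compound 2 (1.54 log units; beyond the scatter), a large step beyond the scatter, in which oxan-4-yl takes the place of 3-fluorophenyl at the same kind of carbon. The amino step, a 2.9-fold higher number from compound 1 to compound 3 (0.46 log units; beyond the scatter), is modest. That group stays in place in compound 4, so this step only sets the starting value.

Going by the values given here, no measured pair shows the loss of 3-fluorophenyl in a compound bearing the amino group, and 1-methylpyrrolidin-2-yl has not been measured. The precedent therefore carries over only loosely. A large upward step is expected in this assay, though somewhat smaller than the precedent. The estimated step is a 16-fold higher number from compound 3 to compound 4 (1.19 log units; beyond the scatter). For compound 4 the estimate is 500000 nM, with an expected range of 120000 nM to 1500000 nM.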

Compound 4, solubility: 760000 nM
Compound 4: middle estimate off by 1.5-fold (0.18 log units), on the low side; low and high end bracket the measured number.
By their numbers in this assay, from the lowest: compound 1; then compound 3; then compounds 2 and 4 (each within the scatter of the next).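

In this assay the large gain at this carbonyl carbon also holds with the amino group present: a 24-fold higher number from compound 3 to compound 4 (1.38 log units; beyond the scatter) is a step of the same large class as a 35-fold higher number from compound 1 to compound 2 (1.54 log units; beyond the scatter). Loss of 3-fluorophenyl has now given a large upward step in both compounds where it can be read, with 1-methylpyrrolidin-2-yl in one and oxan-4-yl in the other, so the effect is tied neither to the compound without the amino group nor to a single entering group, though two pairs are a narrow base and different groups enter in different compounds. Nothing at hand accounts for the size of the step, and the counted differences between the leaving and entering groups remain only a description of the change.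

The compounds shown leave open whether 1-methylpyrrolidin-2-yl gives a comparable step without the amino group, and whether the opposite configuration at its defined stereocentre matches it. They also leave open how an open-chain dimethylamino group, a piperidine ring or a carboxylic acid on the same carbonyl carbon would compare.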